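Second aryl group exchanged: dichlorophenyl in place of methylphenyl

The source may report more compounds than this note shows. Statements on the series, on what has been measured and on what is new or still open speak of the compounds shown alone.

Within the data shown here, compound 2 `Cc1ccccc1C[C@H]1COC(=O)[C@@H]1Cc1ccc(Cl)c(Cl)c1` gives 22000 nM in a functional assay on HL-60 cells (Homo sapiens) for cytotoxicity, read by WST assay, with a stated time of 48 h (a higher number here means that more compound is needed for the effect, a lower number that less compound is needed), the higher of the two numbers so far; compound 1 `CCCCOc1ccccc1C[C@H]1COC(=O)[C@@H]1Cc1ccc(Cl)c(Cl)c1` gives 10000 nM. Among the measured compounds shown here, the only measured step, a 2.2-fold higher number from compound 1 to compound 2 (0.34 log units; beyond the scatter), alters a substituent on an aromatic carbon rather than exchanging the whole aryl group, so it bears only loosely here. Compound 3 `O=C1OC[C@H](Cc2ccc(Cl)c(Cl)c2)[C@H]1Cc1ccc(Cl)c(Cl)c1` differs from compound 2 by 3,4-dichlorophenyl in place of 2-methylphenyl on a saturated chain carbon bound to a saturated ring carbon. For the measured compounds named here, with no matching step measured, a modest move back is expected, a 2.2-fold lower number from compound 2 to compound 3 (0.34 log units; beyond the scatter), of about the size seen before. Compound 3 is estimated at 10000 nM, range 4000 nM to 30000 nM.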

Compound 3, half-maximal effective concentration: 20000 nM
Compound 3: the middle estimate sits 2.0-fold (0.30 log units) below what was measured; measured number inside the range.
By their numbers in this assay, from the lowest: compounds 1, 3 and 2 (each within the scatter of the next, the first and the last beyond it).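

In this assay, 3,4-dichlorophenyl in place of 2-methylphenyl on a saturated chain carbon bound to a saturated ring carbon gives a 1.1-fold lower number from compound 2 to compound 3 (0.04 log units; within the scatter). The earlier step changed only a substituent on an aromatic carbon; this one shows that exchanging the whole aryl group leaves the two compounds indistinguishable in this read-out. Nothing available explains this result.

As far as these compounds go, whether this place needs an aryl group at all remains open. An amine, a carboxylic acid or a plain butyl chain there would test that.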